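Cytotoxicity notes on a quinone series with a methoxy swap

The compounds below may be only part of what the source reports. "The series", "measured", "known", "first", "only" and "open" are said of these compounds alone.

Measured compounds:
compound 1 `COc1ccc(OC)c(C(=O)NCC(C)(C)CC2=C(O)C(=O)c3ccccc3C2=O)c1` gives 89100 nM in an ADME assay on Vero cells (Chlorocebus sabaeus) for cytotoxicity, read by fluorescence, with a stated time of 4 days; a lower number here means a stronger inhibitor, a higher number a weaker inhibitor
compound 2 `COc1cc(C(=O)NCC(C)(C)CC2=C(O)C(=O)c3ccccc3C2=O)c(OC)c2ccccc12` gives 17700 nM in this assay
compound 3 `COC1=C(CC(C)(C)CNC(=O)c2cc(OC)ccc2OC)C(=O)c2ccccc2C1=O` gives 36200 nM in this assay

Compound 1 and compound 3 share a core and differ only where methyl in place of hydrogen on an oxygen on an unsaturated carbon is made. That single change moved the read-out by a 2.5-fold lower number from compound 1 to compound 3 (0.39 log units; beyond the scatter), a step beyond the scatter and modest in size.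

Compound 2 carries a different core than compound 1; the difference between the two cores is not broken down here. Compound 2 has the lowest of the three half-maximal inhibitory concentrations, with compound 3 nearest and compound 1 furthest, both gaps beyond the scatter.

Compound 4 `COC1=C(CC(C)(C)CNC(=O)c2cc(OC)c3ccccc3c2OC)C(=O)c2ccccc2C1=O` has not yet been measured. It stands to compound 2 as compound 3 stands to compound 1: the change is methyl in place of hydrogen on an oxygen on an unsaturated carbon, at the same place word for word, so it is the same change on a different core. The change appears twice among the compounds shown, and only one instance is measured.

Within the data shown here, the step expected here is a 2.2-fold lower number from compound 2 to compound 4 (0.34 log units; beyond the scatter), resting on the single precedent in which compound 1 became compound 3 by a 2.5-fold lower number from compound 1 to compound 3 (0.39 log units; beyond the scatter). Going by these compounds, whether a second core carries the change alike is unknown from these three compounds alone, so the range is kept wide. Compound 4 is expected to give 8000 nM in this assay, between 3500 nM and 18000 nM.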

Compound 4, half-maximal inhibitory concentration: 30100 nM
Compound 4: the middle estimate sits 3.8-fold (0.58 log units) below what was measured; the measured number lies above the stated range.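

In this assay, the hydroxy to methoxy change on the core of compound 2 gives a 1.7-fold higher number from compound 2 to compound 4 (0.23 log units; within the scatter), so on this core the step does not separate the two compounds. Set beside the earlier step, the same change does not carry over alike from the core of compound 1 to the core of compound 2: the same change on two cores in this assay, a 2.5-fold lower number (0.39 log units; beyond the scatter) from compound 1 to compound 3 and a 1.7-fold higher number (0.23 log units; within the scatter) from compound 2 to compound 4, 4.2-fold (0.62 log units) apart, beyond the scatter of two such steps This shows that, in this assay, a step read on one of these two cores cannot simply be transferred to the other, but with only one pair on each core it does not show why the cores part, or whether either step would hold for other compounds on the same core.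

The compounds shown hold only hydrogen or methyl on that oxygen, so what an ethyl group or a longer chain there, or an amine in place of the hydroxy, would give on either core stays open. Also open, going by these compounds, is whether a further core would follow the core of compound 1, the core of compound 2 or neither when this same change is made.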